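Chloro for Methyl in a Series of Weak Antiproliferatives

The source may report more compounds than this note shows. Statements on the series, on what has been measured and on what is new or still open speak of the compounds shown alone.

Compound 1 `C=CC(=O)Nc1cccc(Nc2ncnc(Nc3ccc(-c4cccnc4)cc3)n2)c1` gives in a functional assay on Ramos cells (Homo sapiens) for antiproliferative activity, read by CCK-8 assay, with a stated time of 24 h (on this read-out lower numbers stand for stronger inhibition and higher numbers for weaker inhibition), only a limit, > 100000 nM.
Compound 2 `C=CC(=O)Nc1cccc(Nc2ncnc(Nc3ccc(OC)cc3)n2)c1` gives 90000 nM in this assay.
Compound 3 `C=CC(=O)Nc1cccc(Nc2ncnc(Nc3ccc(-c4ccc(C)nc4)cc3)n2)c1` has no reported result in this assay, its entry reading "not determined" (no result reported).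

Compound 3 therefore stands nowhere on the numbers shown. Of the two values that exist, one is a firm figure for compound 2 and the other is the limit of > 100000 nM in this assay, at which 1 of the 3 values shown sits, which belongs to compound 1 alone.

Compound 4 `C=CC(=O)Nc1cccc(Nc2ncnc(Nc3ccc(-c4ccc(Cl)nc4)cc3)n2)c1` differs from compound 3 by chloro in place of methyl on an aromatic carbon. For the measured compounds named here, the only measured step, an at least 1.1-fold lower number from compound 1 to compound 2 (0.04 log units; that floor lies within the scatter), concerns a different position and lies within the scatter, so it offers no direction for the present change. No step beyond the scatter in this assay is expected either way. Compound 4 is thus estimated at 100000 nM, between 20000 nM and 300000 nM, with a limit quite possible.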

Compound 4, half-maximal inhibitory concentration: 160000 nM
The estimate for compound 4 lay 1.6-fold (0.20 log units) below the measured number; the range from low to high includes it.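

The step to the 6-chloropyridin-3-yl group is a 1.8-fold higher number from compound 2 to compound 4 (0.25 log units; within the scatter), so in this assay this group cannot be told apart from methoxy. The step from compound 1 to compound 4 cannot be read, as compound 1 gives only a limit: the limit of > 100000 nM in this assay, at which 1 of the 4 values shown sits.

As far as these compounds go, compound 3 has no result, so the effect of chloro in place of methyl stays open. Also open, from the compounds shown here alone, is whether an amine or a carboxylic acid on this carbon would give a clearly lower number in this assay.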